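The source may hold more compounds than are shown below. What is called first, only, known or untested is meant among the compounds shown, and "the series" means these compounds.

In a functional assay on MCF7 cells (Homo sapiens) for inhibition, read by fluorescence, with a stated time of 72 h (a higher number here means a weaker inhibitor, a lower number a stronger inhibitor), compound 1 (`CC[C@H](N)COc1nc(NC(=N)N)c2ncn(C(C)C)c2n1`) gives 16300 nM and compound 2 (`CC(C)[C@H](CO)Nc1nc(NC(=N)N)c2ncn(C(C)C)c2n1`) gives 10500 nM so the two stand level within the scatter. For the measured compounds named here, the one measured step is a 1.6-fold lower number from compound 1 to compound 2 (0.19 log units; within the scatter) and it lies within the scatter. Compound 3 (`CC(C)[C@H](N)COc1nc(NC(=N)N)c2ncn(C(C)C)c2n1`) comes from compound 2 by a single change: 2-amino-3-methylbutoxy in place of (1-(hydroxymethyl)-2-methylpropyl)amino on an aromatic carbon with 2-amino-3-methylbutoxy in place of (1-(hydroxymethyl)-2-methylpropyl)amino on an aromatic carbon between two ring nitrogen atoms. The entering chain is close in name to the 2-aminobutoxy of compound 1, so the measured step bears almost directly on this one, run nearly in reverse. A step within the scatter is therefore expected in this assay. Compound 1 at 16300 nM is the nearest guide. The expected change is a 1.2-fold higher number from compound 2 to compound 3 (0.09 log units; within the scatter) which stays inside the scatter. For compound 3 the estimated value is 13000 nM with a range from 5500 nM to 30000 nM expected around it.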

Compound 3, half-maximal inhibitory concentration: 3400 nM
Compound 3: middle estimate off by 3.8-fold (0.58 log units), on the high side, outside the stated range (below it).
By their numbers in this assay, from the lowest: compound 3; then compounds 2 and 1 (each within the scatter of the next).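

In this assay, the exchange of (1-(hydroxymethyl)-2-methylpropyl)amino for 2-amino-3-methylbutoxy on this aromatic carbon gives a 3.1-fold lower number from compound 2 to compound 3 (0.49 log units; beyond the scatter), so two chains of the same atoms, joined differently, are not interchangeable here. The earlier swap of chains at this carbon stayed within the scatter, but a single methyl in place of hydrogen on the saturated chain carbon gives a 4.8-fold lower number from compound 1 to compound 3 (0.68 log units; beyond the scatter), which separates compound 3 from its closest relative, compound 1. No measurement shown gives a reason for either step.

The compounds shown leave open whether a longer chain, such as an ethyl or a phenyl group on that same saturated carbon, would lower the number further. They also leave open whether the amine of the 2-amino-3-methylbutoxy chain could give way to a hydroxyl.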